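The compounds below may be only part of what the source reports. "The series", "measured", "known", "first", "only" and "open" are said of these compounds alone.

Measured so far:
- Compound 1 `Nc1nc(N/N=C/c2ccc3ncccc3c2)nc2c1ncn2[C@@H]1O[C@H](CO)[C@@H](O)[C@H]1O`: 9.8 nM
- Compound 2 `Nc1nc(N/N=C/c2ccc(-c3ccccn3)cc2)nc2c1ncn2[C@@H]1O[C@H](CO)[C@@H](O)[C@H]1O`: 7540 nM
- Compound 3 `Nc1nc(N/N=C/C2CCCC2)nc2c1ncn2[C@@H]1O[C@H](CO)[C@@H](O)[C@H]1O`: 5.6 nM

In an assay on CHO-K1 cells for displacement of a labelled ligand from adenosine receptor A1 (Homo sapiens), read by scintillation counting, with a stated time of 60 min (a higher number here means a weaker inhibitor, a lower number a stronger inhibitor), compound 3 gives the lowest of the three numbers. Its nearest neighbour is compound 1, and the step of a 1.8-fold lower number from compound 1 to compound 3 (0.24 log units; within the scatter) lies within the scatter, so the two cannot be told apart. Compound 2 stands far away: in this assay compound 2 gives 7540 nM, whereas compound 3 gives 5.6 nM, a gap well beyond the scatter.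

Compound 4 `Nc1nc(N/N=C/c2ccc(C(F)(F)F)cc2)nc2c1ncn2[C@@H]1O[C@H](CO)[C@@H](O)[C@H]1O` has not yet been measured. It differs from compound 3 in one place: 4-(trifluoromethyl)phenyl in place of cyclopentyl on a carbon with a double bond to nitrogen. Among the measured compounds shown here, the only step that bears on an exchange at this carbon is the one from compound 1 to compound 3, where an aromatic ring gave way to cyclopentyl with no change beyond the scatter. For the measured compounds named here, the very high number of compound 2, however, shows that a different substituted phenyl at the same place can sit far away, and no step between compound 2 and compound 3 has been computed. The outcome for a trifluoromethyl-bearing phenyl is therefore open, and a weaker value than compound 3 is expected in this assay, as an 11-fold higher number from compound 3 to compound 4 (1.03 log units; beyond the scatter).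

Compound 4 is estimated at 60 nM, with a range from 6 nM to 600 nM.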

Compound 4, inhibition constant: 37 nM
For compound 4 the middle estimate is 1.6-fold (0.21 log units) above the measured one; measured number inside the range.
By their numbers in this assay, from the lowest: compounds 3 and 1 (each within the scatter of the next); then compound 4; then compound 2.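

In this assay, 4-(trifluoromethyl)phenyl in place of cyclopentyl on the carbon with a double bond to nitrogen gives a 6.6-fold higher number from compound 3 to compound 4 (0.82 log units; beyond the scatter) and so shows a modest but real change at this position, which the exchange of quinolin-6-yl for cyclopentyl did not. Having an aromatic ring at this place does not settle the number on its own, since 4-(trifluoromethyl)phenyl in place of quinolin-6-yl gives a 3.8-fold higher number from compound 1 to compound 4 (0.58 log units; beyond the scatter) and separates two aromatic groups. The largest new step comes from the group on the phenyl ring: trifluoromethyl in place of pyridin-2-yl on an aromatic carbon gives a 200-fold lower number from compound 2 to compound 4 (2.31 log units; beyond the scatter) and shows that the very weak result for compound 2 does not apply to every substituted phenyl at this position.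

The compounds shown leave open how a phenyl ring carrying an amine or a carboxylic acid in place of trifluoromethyl would fall within this range. Nothing given here explains why these groups differ in this way.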